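Pyridin-2-yl for cyclopropyl on the ring nitrogen of compound 1

The source may report more compounds than this note shows. Statements on the series, on what has been measured and on what is new or still open speak of the compounds shown alone.

Measured so far in a functional assay on CCRF-CEM cells for antagonist activity at C-X-C chemokine receptor type 4 (Homo sapiens), read by calcium flux, with stated times of 25 min and 90 s; on this read-out lower numbers stand for stronger inhibition and higher numbers for weaker inhibition:
compound 1 `CN(C[C@H]1Cc2c(cccc2N2CCN(C3CC3)CC2)CN1)[C@H]1CCCc2cccnc21` gives 23.5 nM
compound 2 `C[C@@H]1CN(c2cccc3c2C[C@H](CN(C)[C@H]2CCCc4cccnc42)NC3)C[C@H](C)N1` gives 61 nM
compound 3 `C[C@@H]1CN(c2cccc3c2C[C@H](CN(C)[C@H]2CCCc4cccnc42)NC3)C[C@H](C)N1C` gives 14.1 nM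

Compound 1 stands second highest of the three numbers. Its nearest neighbour is compound 3, with a 1.7-fold lower number from compound 1 to compound 3 (0.22 log units; within the scatter), a gap within the scatter; its furthest is compound 2, with a 2.6-fold higher number from compound 1 to compound 2 (0.41 log units; beyond the scatter), a modest step beyond the scatter. The remaining pair shows a 4.3-fold lower number from compound 2 to compound 3 (0.64 log units; beyond the scatter), again modest and beyond the scatter, from methyl in place of hydrogen on an amine nitrogen in a ring.

Compound 4 `CN(C[C@H]1Cc2c(cccc2N2CCN(c3ccccn3)CC2)CN1)[C@H]1CCCc2cccnc21` differs from compound 1 in one place: pyridin-2-yl in place of cyclopropyl on an amine nitrogen in a ring. Within the data shown here, none of the measured steps exchanges cyclopropyl for an aromatic group; two of them swap the whole group on the aromatic carbon, and one adds methyl on an amine nitrogen in a ring. They bear on compound 4 only in showing that changes around this six-membered non-aromatic ring with 2 nitrogen have so far moved the number by modest steps in either direction, never by large ones. A step of similar size is therefore expected for compound 4, with the direction not fixed by the data.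

The estimate for compound 4 in this assay is 35 nM, within 10 nM to 120 nM, which means an expected step of a 1.5-fold higher number from compound 1 to compound 4 (0.17 log units; within the scatter).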

Compound 4, half-maximal inhibitory concentration: 17.9 nM
For compound 4 the middle estimate is 2.0-fold (0.29 log units) above the measured one, within the range that was stated.
By their numbers in this assay, from the lowest: compounds 3, 4 and 1 (each within the scatter of the next); then compound 2.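

In this assay, pyridin-2-yl in place of cyclopropyl on the amine nitrogen in a ring gives a 1.3-fold lower number from compound 1 to compound 4 (0.12 log units; within the scatter), so a six-membered aromatic ring with 1 hetero atom can replace a three-membered non-aromatic ring of carbon only without a step beyond the scatter. Among these compounds, the earlier compounds carried only hydrogen, methyl or cyclopropyl on this nitrogen, so compound 4 is the first to show that this position accepts an aromatic group, with 6 heavy atoms entering for 3 and a hydrogen-bond acceptor gained, while the number stays within the scatter of that of compound 1. No measurement on these compounds offers an explanation for this result.

As far as these compounds go, whether the ring nitrogen of pyridin-2-yl contributes remains open, and phenyl on the same amine nitrogen would separate the effect of the aromatic ring from that of its hetero atom. From the compounds shown here alone, how much more this position can accept also remains open, and benzyl or acetyl on that nitrogen would test whether a linked aromatic ring or a carbonyl fits the same pattern.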